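From 1-benzothiophen-3-yl to 1-benzothiophen-5-yl: working notes

A few compounds are considered here, and "the series" means these few. Any claim that something is new, unique, unknown or untested is made for them only; others in the source may bear on it.

Measured so far in a physicochemical assay for lipophilicity, measured as octanol-water partition, at pH 7.4; on this read-out higher numbers stand for higher lipophilicity and lower numbers for lower lipophilicity:
- compound 1 `Cc1cccc(C)c1-c1cccc(COc2ccc3c(c2)OCC3CC(=O)O)c1` at 3.88
- compound 2 `Cc1cccc(C)c1-c1cccc(COc2ccc3c(c2)CC3CC(=O)O)c1` at 4.12
- compound 3 `O=C(O)CC1COc2cc(OCc3cccc(-c4csc5ccccc45)c3)ccc21` at 3.99

Compound 3 at 3.99 lies within the scatter of both other compounds, so the three numbers give no firm order. Compound 4 `O=C(O)CC1COc2cc(OCc3cccc(-c4ccc5sccc5c4)c3)ccc21` has the same atoms as compound 3, joined differently, with 1-benzothiophen-5-yl in place of 1-benzothiophen-3-yl on an aromatic carbon. For the measured compounds named here, the only measured step at this place is a number 0.11 log units higher from compound 1 to compound 3 (within the scatter) and it brings in the 1-benzothiophen-3-yl group itself. A step of that size gives no ground for expecting a shift in this assay between two attachments of one group. The expected outcome is a number 0.06 log units higher from compound 3 to compound 4 (within the scatter) and so no step beyond the scatter. Compound 4 is estimated at 4.05 with 3.7 to 4.4 as the expected range.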

Compound 4, distribution coefficient: 3.97
Beside the measured number, compound 4's estimate is 0.08 log units above it; the measured number falls inside the stated range.
By their numbers in this assay, from the lowest: compounds 1, 4, 3 and 2 (each within the scatter of the next).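

The step of a number 0.02 log units lower from compound 3 to compound 4 (within the scatter) in this assay shows that moving from 1-benzothiophen-3-yl to 1-benzothiophen-5-yl on this aromatic carbon leaves the read-out within the scatter. The step of a number 0.09 log units higher from compound 1 to compound 4 (within the scatter) places 1-benzothiophen-5-yl, like 1-benzothiophen-3-yl, within the scatter of 2,6-dimethylphenyl at this place. Nothing at hand gives a cause for either step.

As far as these compounds go, whether an amine or a carboxylic acid at this place would give a step beyond the scatter stays open. From the compounds shown here alone, whether the two attachments differ in any other read-out also stays open.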